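An amide replaces the aryl ketone in compound 4

This account rests on a few compounds, and the source may have more. Where it says the series, first, only, none or still open, it means among the compounds named here.

Compound 3 `COc1cc(-c2nnc(SCC(=O)c3ccc(F)c(F)c3)n2N)cc(OC)c1OC` is one of three measured members of a shared core. In a functional assay on HepG2 cells (Homo sapiens) for antiproliferative activity, read by MTT assay, with a stated time of 48 h (on this read-out higher numbers stand for weaker inhibition and lower numbers for stronger inhibition), compound 3 gives > 100000 nM, which is a limit of the assay and not a number. Compound 1 `COc1cc(-c2nnc(SCC(=O)c3ccc(Cl)cc3)n2N)cc(OC)c1OC` likewise reaches only a limit, > 100000 nM. Compound 2 `COc1cc(-c2nnc(SCC(=O)c3cccc(Br)c3)n2N)cc(OC)c1OC` gives 56000 nM in this assay. The step of an at least 1.7-fold lower number from compound 1 to compound 2 (0.25 log units; that floor lies within the scatter) and the step of an at least 1.7-fold higher number from compound 2 to compound 3 (0.25 log units; that floor lies within the scatter) are both read against (the limit of > 100000 nM in this assay, at which 2 of the 3 values shown sit), and the step that the two limits leave unreadable from compound 1 to compound 3 cannot be read at all. Compound 4 `COc1cccc(NC(=O)CSc2nnc(-c3cc(OC)c(OC)c(OC)c3)n2N)c1` differs from compound 3 by (3-methoxyphenyl)amino in place of 3,4-difluorophenyl on a carbonyl carbon. Among the compounds with values here, none of the measured steps exchanges the aryl ketone for such an amino group; they only vary the halogens on the ring, and all three results sit at the weak end of this assay. Compound 4 is therefore expected to stay near that end, with a step of an at least 1.1-fold lower number from compound 3 to compound 4 (0.04 log units; that floor lies within the scatter) that is estimated to lie within the scatter. The estimate for compound 4 is 90000 nM, with a range from 30000 nM to 300000 nM.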

Compound 4, half-maximal inhibitory concentration: > 100000 nM
Compound 4 was reported as a limit; the forecaster's own chance of this, stated with the estimate: 55%; at least 1.1-fold (0.04 log units) between middle value and limit.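

In this assay compound 4 gives > 100000 nM, which is a limit of the assay and not a number. This is the first change shown that replaces the aryl ketone with an amide, and the only step it allows to be read is an at least 1.7-fold higher number from compound 2 to compound 4 (0.25 log units; that floor lies within the scatter), while the steps to compound 4 from compound 1 and from compound 3 cannot be read. The amide therefore yields no numerical value, and compound 2 remains the only compound of the four with one, so the comparison is bounded by the assay limit: the limit of > 100000 nM in this assay, at which 3 of the 4 values shown sit.

From the compounds shown here alone, how far compounds 1, 3 and 4 differ from one another stays open. So does whether a morpholine amide, a carboxylic acid or a longer chain on this carbonyl carbon would give a numerical value in this assay.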